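From compound 1 to compound 3: an expected step

The source may hold more compounds than are shown below. What is called first, only, known or untested is meant among the compounds shown, and "the series" means these compounds.

Measured in an ADME assay for permeability, using PAMPA, with a stated time of 4 h, at pH 7.4; on this read-out lower numbers stand for lower permeability and higher numbers for higher permeability:
compound 1 `c1ccc2c(c1)CN[C@@H](CN(CCC1CCNCC1)[C@H]1CCCc3cccnc31)C2` gives 19 nm/s
compound 2 `c1cnc(CN(CCCN2CCNCC2)[C@H]2CCCc3cccnc32)nc1` gives 31 nm/s

Compound 1 (19 nm/s) lies within the usual scatter of compound 2 (31 nm/s), so the two cannot be ranked. Compound 3 `CN1CCN(CCCN(C[C@H]2Cc3ccccc3CN2)[C@H]2CCCc3cccnc32)CC1` has not yet been measured. It differs from compound 1 by one change ((4-methylpiperazin-1-yl)methyl in place of piperidin-4-yl on a saturated chain carbon, two bonds along the chain from an amine nitrogen). For the measured compounds named here, no measured pair shows what such a change does, so no step beyond the scatter is expected in this assay. The expected step (a 1.3-fold higher number from compound 1 to compound 3 (0.12 log units; within the scatter)) stays within the scatter. Compound 3 is estimated at 25 nm/s (range 10 nm/s to 60 nm/s).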

Compound 3, apparent permeability: 360 nm/s
Compound 3: the middle estimate sits 14-fold (1.16 log units) below what was measured, outside the stated range (above it).
By their numbers in this assay, from the lowest: compounds 1 and 2 (each within the scatter of the next); then compound 3.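

This position is not silent in this assay: on a saturated chain carbon, two bonds along the chain from an amine nitrogen, (4-methylpiperazin-1-yl)methyl in place of piperidin-4-yl gives a large step (a 19-fold higher number from compound 1 to compound 3 (1.28 log units; beyond the scatter)). The earlier compounds shown here, which differ in more than one place, could not show what a single change here does. No measurement at hand explains the step.

From the compounds shown here alone, it remains open which part of the change carries the step: the methyl, the second ring nitrogen or the longer chain. A morpholine or an unsubstituted piperazine on the same core would begin to separate these.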